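Swapping chloro for tert-butyl on the amide-linked phenyl ring

A few compounds are considered here, and "the series" means these few. Any claim that something is new, unique, unknown or untested is made for them only; others in the source may bear on it.

Compound 3 `CCOc1nc2c(c(=O)n(C)c(=O)n2C)n1CC(=O)Nc1ccc(Cl)cc1` was tested in an assay on isolated protein for inhibition of high affinity 3',5'-cyclic-AMP phosphodiesterase 7A (Homo sapiens), read by cAMP accumulation, with a stated time of 10 min (a higher number here means a weaker inhibitor, a lower number a stronger inhibitor), and returned only a limit, > 200000 nM. Compound 2 `CCOc1nc2c(c(=O)n(C)c(=O)n2C)n1CC(=O)Nc1cccc(Cl)c1`, which carries the chlorine at a different place on the same ring, likewise gave only a limit, > 200000 nM. The move between them, a step that the two limits leave unreadable from compound 2 to compound 3, therefore cannot be read as a number; both values sit at the limit of > 200000 nM in this assay, at which 2 of the 3 values shown sit. A third compound, compound 1 `COc1nc2c(c(=O)n(C)c(=O)n2C)n1CCCC(=O)Nc1ccc(C(C)(C)C)cc1`, differs from compound 3 in more than one place, and in this assay compound 1 gives 19800 nM, a real number rather than a limit. Compound 4 `CCOc1nc2c(c(=O)n(C)c(=O)n2C)n1CC(=O)Nc1ccc(C(C)(C)C)cc1` is reached from compound 3 by tert-butyl in place of chloro on an aromatic carbon. No measured step covers this change on its own, so its size is not known from the numbers shown. Since compound 3 stands at a limit, only a gain in potency beyond the scatter could show as a number, and such a gain is estimated as plausible but uncertain, an at least 1.6-fold lower number from compound 3 to compound 4 (0.22 log units; that floor lies within the scatter). For compound 4 the expected value in this assay is 120000 nM, within a range from 25000 nM to 300000 nM.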

Compound 4, half-maximal inhibitory concentration: > 200000 nM
Compound 4: no number, only a limit; the forecaster's own chance of this, stated with the estimate: 50%; middle value at least 1.6-fold (0.22 log units) away from the limit.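

Compound 4 also returned only a limit in this assay, so the steps to it from compound 2 and compound 3 cannot be read as numbers: the limit of > 200000 nM in this assay, at which 3 of the 4 values shown sit. The compounds shown leave open which of its differences from compound 4 gives compound 1 its measured value of 19800 nM.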